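The source may hold more compounds than are shown below. What is called first, only, known or untested is meant among the compounds shown, and "the series" means these compounds.

Compound 1 `COc1cc(C2=NN(C(C)=O)C(c3cccc(OC)c3OC)O2)cc(OC)c1OC`, compound 2 `COc1ccc(C2OC(c3cc(OC)c(OC)c(OC)c3)=NN2C(C)=O)c(OC)c1` and compound 3 `COc1cc(C2=NN(C(C)=O)C(c3ccccc3C(F)(F)F)O2)cc(OC)c1OC` share one core and differ only in the aryl group on a saturated ring carbon. In a functional assay on PC-3 cells (Homo sapiens) for antiproliferative activity, read by MTT assay, tested at 5 uM (a lower number here means a weaker effect, a higher number a stronger effect of the compound at the concentration tested), compound 1 gives 58.2%, compound 2 gives 92% and compound 3 gives 15.2%. Compound 3 stands lowest of the three: the step of a number 43 percentage points lower from compound 1 to compound 3 (beyond the scatter) and the step of a number 76.8 percentage points lower from compound 2 to compound 3 (beyond the scatter) both run downward, while the step of a number 33.8 percentage points higher from compound 1 to compound 2 (beyond the scatter) shows that the two dimethoxyphenyl compounds themselves lie far apart. Compound 4 `COc1cc(C2=NN(C(C)=O)C(c3ccc(F)cc3)O2)cc(OC)c1OC` is not yet measured; it differs from compound 3 by 4-fluorophenyl in place of 2-(trifluoromethyl)phenyl on a saturated ring carbon. The two measured steps that bear on this change are those leading into compound 3, and both were large and downward, so leaving the 2-(trifluoromethyl)phenyl group has only been seen to matter a great deal. For the measured compounds named here, no measured compound carries 4-fluorophenyl, so the direction here rests on that alone. Compound 4 is expected to move upward by a number 24.8 percentage points higher from compound 3 to compound 4 (beyond the scatter) in this assay, to an estimated 40% within a range from 15% to 70%.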

Compound 4, a percentage reported as inhibition, at one concentration (the size of the read-out at that concentration, not a potency): 0.1%
The estimate for compound 4 lay 39.9 percentage points above the measured number; the measured number lies below the stated range.
By their numbers in this assay, from the lowest: compound 4; then compound 3; then compound 1; then compound 2.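

Moving from 2-(trifluoromethyl)phenyl to 4-fluorophenyl did not restore activity in this assay; the number fell further (a number 15.1 percentage points lower from compound 3 to compound 4 (beyond the scatter)), so the large drops into compound 3 did not depend on the 2-(trifluoromethyl)phenyl group alone. Compound 4 also lies far from both dimethoxyphenyl compounds (a number 91.9 percentage points lower from compound 2 to compound 4 (beyond the scatter); a number 58.1 percentage points lower from compound 1 to compound 4 (beyond the scatter)). Across these four compounds, the two aryl groups bearing fluorine give the lowest numbers and the two dimethoxyphenyl groups the highest, with no compound going against that split, and a simple 4-fluorophenyl group at this position leaves almost no effect at the concentration tested.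

The compounds shown leave open whether a single methoxy group or a dimethylamino group on this aryl ring would recover the number. No measurement available here explains any of these steps.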